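The compounds below may be only part of what the source reports. "The series", "measured", "known", "first", "only" and "open" are said of these compounds alone.

Compound 1, `COc1cc2nccc(Oc3ccc(Nc4nn(C)cc4C(=O)NC4CCCCC4)cc3)c2cc1C(N)=O`, gives 4800 nM in a functional assay on BaF3 cells (Mus musculus) for antiproliferative activity, read by CCK-8 assay and cell counting, with a stated time of 76 h; a lower number here means a stronger inhibitor, a higher number a weaker inhibitor.
Compound 2, `COc1cc2nccc(Oc3ccc(Nc4nn(C)cc4C(=O)Nc4ccc(F)cc4)cc3)c2cc1C(N)=O`, gives 3060 nM in this assay.

Compound 1 shows the higher of the two numbers, though a 1.6-fold lower number from compound 1 to compound 2 (0.20 log units; within the scatter) is within the scatter. Compound 3, `COc1cc2nccc(Oc3ccc(Nc4nn(C)cc4C(=O)NCC4CCCCC4)cc3)c2cc1C(N)=O`, differs from compound 1 by cyclohexylmethyl in place of cyclohexyl on an amide-type nitrogen. Among the measured compounds shown here, no measured step makes this change; the only step at the same amide-type nitrogen, a 1.6-fold lower number from compound 1 to compound 2 (0.20 log units; within the scatter), stays within the scatter, so no clear direction is indicated. For compound 3 in this assay a step within the scatter is therefore expected, a 1.2-fold lower number from compound 1 to compound 3 (0.08 log units; within the scatter). Compound 3 is estimated at 4000 nM, with a range from 1500 nM to 12000 nM.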

Compound 3, half-maximal inhibitory concentration: > 10000 nM
Compound 3 ended at the assay's limit; the forecaster's own chance of this, stated with the estimate: 5%; at least 2.5-fold (0.39 log units) between middle value and limit.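

Compound 3 gives > 10000 nM in this assay, which is a limit of the assay and not a number. Where cyclohexyl and 4-fluorophenyl on the amide-type nitrogen stayed within the scatter of each other, cyclohexylmethyl at the same place moves the number beyond it, with an at least 2.0-fold higher number from compound 1 to compound 3 (0.31 log units; beyond the scatter) and an at least 3.2-fold higher number from compound 2 to compound 3 (0.51 log units; beyond the scatter). Both steps are minimum sizes, resting on a single value: the limit of > 10000 nM in this assay, at which 1 of the 3 values shown sits.

As far as these compounds go, how far past the limit compound 3 lies remains open. So does whether benzyl, or a longer chain such as cyclohexylethyl, on this nitrogen would behave like cyclohexylmethyl.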